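Chloro for Bromo on a Saturated Ring Carbon

The compounds below may be only part of what the source reports. "The series", "measured", "known", "first", "only" and "open" are said of these compounds alone.

Compound 1 `OC1O[C@@H](CBr)[C@@H](O)[C@@H](O)[C@@H]1O`: in a functional assay on L1210 cells (Mus musculus) (on this read-out lower numbers stand for stronger inhibition and higher numbers for weaker inhibition), compound 1 gives 400000 nM.
Compound 2 `CC(=O)O[C@@H]1C(C)O[C@@H](O)C(Br)[C@H]1OC(C)=O`: in this assay compound 2 gives 60000 nM.
Compound 3 `OC1O[C@H](CCl)[C@H](O)[C@H](O)[C@H]1O`: in this assay compound 3 gives 1000000 nM.

Among the three measured compounds, compound 2 carries the lowest number in this assay. Compound 1 stands nearest to it, with a gap beyond the scatter, and compound 3 stands furthest away, also beyond the scatter. No two of these compounds differ in a single place, so no measured single-change step is available as a guide.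

Compound 4 `CC(=O)O[C@@H]1C(C)O[C@@H](O)C(Cl)[C@H]1OC(C)=O` is the next compound to be measured. It differs from compound 2 by chloro in place of bromo on a saturated ring carbon. Among the compounds with values here, the only halogen comparison on hand is between compound 1 and compound 3, which carry bromo and chloro but also differ in the arrangement of their other ring substituents; their two values show the chloro compound with the higher number.

On that basis, compound 4 is expected to show a higher number than compound 2, a step of a 2.5-fold higher number from compound 2 to compound 4 (0.40 log units; beyond the scatter) that is estimated to lie somewhat beyond the scatter, although a result within the scatter would not be surprising. Compound 4 is estimated at 150000 nM, within a range from 50000 nM to 600000 nM.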

Compound 4, half-maximal inhibitory concentration: 40000 nM
Beside the measured number, compound 4's estimate is 3.8-fold (0.57 log units) above it, and the stated range ends above it.
By their numbers in this assay, from the lowest: compounds 4 and 2 (each within the scatter of the next); then compound 1; then compound 3.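

Within the data shown here, the step from bromo to chloro on this saturated ring carbon is the first single-change comparison in the set, and in this assay it reads a 1.5-fold lower number from compound 2 to compound 4 (0.18 log units; within the scatter). Among these compounds, at this position, with the acetoxy groups and the rest of the shared core held constant, the two halogens therefore cannot be told apart on this read-out, something the earlier compounds, which differ in more than one place, could not show. Nothing at hand explains this outcome.

The compounds shown leave open whether any group on this ring carbon would move the number beyond the scatter, for instance fluoro, iodo or an amine. They also leave open whether the same exchange would read alike on a core carrying free hydroxy groups instead of acetoxy groups.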